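Working notes: chloro in place of nitro

A few compounds are considered here, and "the series" means these few. Any claim that something is new, unique, unknown or untested is made for them only; others in the source may bear on it.

The series shares the core of compound 1 (`C=C1C(=O)[C@@]23C(=O)OC[C@]4(C(=O)CCC(C)(C)[C@H]4C=O)[C@@H]2CC[C@@H]1[C@H]3OC(=O)c1ccc(OC)cc1`) and varies only one aromatic substituent. In a functional assay on MGC-803 cells (Homo sapiens) for cytotoxicity, read by MTT assay, with a stated time of 72 h (on this read-out higher numbers stand for weaker inhibition and lower numbers for stronger inhibition), compound 1 gives 1870 nM, compound 2 (`C=C1C(=O)[C@@]23C(=O)OC[C@]4(C(=O)CCC(C)(C)[C@H]4C=O)[C@@H]2CC[C@@H]1[C@H]3OC(=O)c1ccc(C(F)(F)F)cc1`) gives 4930 nM and compound 3 (`C=C1C(=O)[C@@]23C(=O)OC[C@]4(C(=O)CCC(C)(C)[C@H]4C=O)[C@@H]2CC[C@@H]1[C@H]3OC(=O)c1ccc([N+](=O)[O-])cc1`) gives 3330 nM. The value of compound 3 lies within the scatter of both other values, although those two values differ from each other beyond it.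

The next structure is compound 4 (`C=C1C(=O)[C@@]23C(=O)OC[C@]4(C(=O)CCC(C)(C)[C@H]4C=O)[C@@H]2CC[C@@H]1[C@H]3OC(=O)c1ccc(Cl)cc1`), with chloro in place of nitro on an aromatic carbon, para to a large group: chloro in place of nitro on an aromatic carbon. Within the data shown here, no measured compound carries chloro, so the evidence is indirect. Three exchanges at this same carbon bear on it. Trifluoromethyl in place of methoxy gave a 2.6-fold higher number from compound 1 to compound 2 (0.42 log units; beyond the scatter), a modest step beyond the scatter. Nitro in place of methoxy gave a 1.8-fold higher number from compound 1 to compound 3 (0.25 log units; within the scatter), and nitro in place of trifluoromethyl gave a 1.5-fold lower number from compound 2 to compound 3 (0.17 log units; within the scatter), both within the scatter.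

With steps of this size at this carbon, no change beyond the scatter is expected in this assay, and no direction is favoured. The expected change is a 1.1-fold lower number from compound 3 to compound 4 (0.05 log units; within the scatter). For compound 4 the estimated value is 3000 nM, with an expected range of 1500 nM to 6000 nM.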

Compound 4, half-maximal inhibitory concentration: 3120 nM
Compound 4: the middle estimate sits 1.0-fold (0.02 log units) below what was measured; measured number inside the range.
By their numbers in this assay, from the lowest: compounds 1, 4, 3 and 2 (each within the scatter of the next, the first and the last beyond it).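

In this assay chloro in place of nitro gives a 1.1-fold lower number from compound 3 to compound 4 (0.03 log units; within the scatter), so at this aromatic carbon, para to a large group, nitro with its hydrogen-bond acceptors gives way to chloro with none and the step stays within the scatter. Chloro in place of trifluoromethyl gives a 1.6-fold lower number from compound 2 to compound 4 (0.20 log units; within the scatter) and chloro in place of methoxy gives a 1.7-fold higher number from compound 1 to compound 4 (0.22 log units; within the scatter); compound 4 therefore lies within the scatter of all three earlier compounds, and the step from compound 1 to compound 2 remains the only one of the series beyond it. Nothing measured in this set accounts for any of these steps.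

The four substituents shown leave open whether an amine or a carboxylic acid on this same carbon would move the number beyond the scatter of compound 4. Also open, from the compounds shown here alone, is whether a longer chain such as n-butyl in place of the 4-chlorophenyl would keep the number within that scatter or shift it in either direction.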